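The source may report more compounds than this note shows. Statements on the series, on what has been measured and on what is new or still open speak of the compounds shown alone.

Measured so far:
- compound 1 `CC(C(=O)NCc1ccc(C(F)(F)F)nc1N(Cc1ccc(F)cc1)S(=O)(=O)c1ccc(F)cc1)c1ccc(NS(C)(=O)=O)c(F)c1` — 2.99 nM
- compound 2 `COc1ccc(CN(c2nc(C(F)(F)F)ccc2CNC(=O)C(C)c2ccc(NS(C)(=O)=O)c(F)c2)S(=O)(=O)c2ccc(F)cc2)cc1` — 7.9 nM

Both numbers come from an assay on CHO cells for antagonist activity at transient receptor potential cation channel subfamily V member 1 (Homo sapiens), read by scintillation counting, with a stated time of 5 min; a higher number here means a weaker inhibitor, a lower number a stronger inhibitor. Compound 2 stands at the higher of the two numbers, the weaker inhibitor, with compound 1 as its only neighbour; the one step shown, methoxy in place of fluoro on an aromatic carbon, reads a 2.6-fold higher number from compound 1 to compound 2 (0.42 log units; beyond the scatter) in this assay.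

Compound 3 `Cc1ccc(CN(c2nc(C(F)(F)F)ccc2CNC(=O)C(C)c2ccc(NS(C)(=O)=O)c(F)c2)S(=O)(=O)c2ccc(F)cc2)cc1` differs from compound 2 by methyl in place of methoxy on an aromatic carbon, the same place that carried fluoro in compound 1 and methoxy in compound 2. Among the measured compounds shown here, no measured step swaps methyl for methoxy; the single known step tells only that fluoro and methoxy at this place differ modestly. The expectation is therefore a small step, if any, towards a lower number in this assay, a 1.3-fold lower number from compound 2 to compound 3 (0.12 log units; within the scatter), and compound 3 is estimated at 6 nM, with a range from 2.5 nM to 15 nM.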

Compound 3, inhibition constant: 7.08 nM
For compound 3 the middle estimate is 1.2-fold (0.07 log units) below the measured one; low and high end bracket the measured number.
By their numbers in this assay, from the lowest: compound 1; then compounds 3 and 2 (each within the scatter of the next).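

Swapping the methoxy of the 4-methoxybenzyl group for methyl, which gives the 4-methylbenzyl group, makes no difference that can be told apart in this assay (a 1.1-fold lower number from compound 2 to compound 3 (0.05 log units; within the scatter)), even though one heavy atom and the only hydrogen-bond acceptor of the methoxy group are gone. Methyl in place of fluoro gives a step (a 2.4-fold higher number from compound 1 to compound 3 (0.37 log units; beyond the scatter)) close to that of methoxy in place of fluoro (a 2.6-fold higher number from compound 1 to compound 2 (0.42 log units; beyond the scatter)), so at this place compound 1, with fluoro, stands apart from the other two, and both steps are modest. Nothing measured on these compounds gives a reason for this.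

Still open, going by these compounds, is what an amine, a carboxylic acid or a longer chain such as butoxy would do at this place. On these data alone, whether a chlorine would sit with fluoro or with methyl and methoxy is also open.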